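The compounds below may be only part of what the source reports. "The series", "measured", "known", "first", "only" and "open" are said of these compounds alone.

Of the compounds shown here, three built on one shared core have been tested in an ADME assay on MT4 cells (Homo sapiens) for cytotoxicity, read by MTT assay, with a stated time of 4 days; on this read-out lower numbers stand for higher toxicity in this test and higher numbers for lower toxicity in this test. Compound 1 `Cc1cc(-c2ccccc2C(F)(F)F)cc(C)c1Nc1ccnc(Nc2ccc(C#N)cc2)n1` gives 4210 nM, compound 2 `Cc1cc(C)cc(-c2cc(C)c(Nc3ccnc(Nc4ccc(C#N)cc4)n3)c(C)c2)c1` gives 4140 nM, and compound 3 `COc1ccc(-c2cc(C)c(Nc3ccnc(Nc4ccc(C#N)cc4)n3)c(C)c2)cc1` gives 2890 nM. Compound 3 carries the lowest of the three numbers, yet the steps of a 1.5-fold lower number from compound 1 to compound 3 (0.16 log units; within the scatter) and a 1.4-fold lower number from compound 2 to compound 3 (0.16 log units; within the scatter) both fall within the scatter, so the three cannot really be told apart. Compound 4 `Cc1cc(-c2ccc(C(F)(F)F)cc2)cc(C)c1Nc1ccnc(Nc2ccc(C#N)cc2)n1` differs from compound 3 by trifluoromethyl in place of methoxy on an aromatic carbon. Within the data shown here, no measured step exchanges a methoxy for a trifluoromethyl; the closest guide is that swapping one substituted phenyl for another, as in a 1.0-fold lower number from compound 1 to compound 2 (0.01 log units; within the scatter) and the two steps just named, barely moved this assay. A step of about a 1.2-fold higher number from compound 3 to compound 4 (0.08 log units; within the scatter) is therefore expected, nothing beyond the scatter. Compound 4 is estimated at 3500 nM, probably between 1800 nM and 7000 nM.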

Compound 4, half-maximal cytotoxic concentration: 4160 nM
The estimate for compound 4 lay 1.2-fold (0.08 log units) below the measured number; low and high end bracket the measured number.
By their numbers in this assay, from the lowest: compounds 3, 2, 4 and 1 (each within the scatter of the next).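

Trifluoromethyl in place of methoxy, para to a large group, gives a 1.4-fold higher number from compound 3 to compound 4 (0.16 log units; within the scatter) in this assay and so stays within the scatter. The same holds for 4-(trifluoromethyl)phenyl in place of 2-(trifluoromethyl)phenyl, with a 1.0-fold lower number from compound 1 to compound 4 (0.01 log units; within the scatter) as the step, and in place of 3,5-dimethylphenyl, with a 1.0-fold higher number from compound 2 to compound 4 (0.00 log units; within the scatter) as the step, so the position of trifluoromethyl on this phenyl made no readable difference among these compounds. No outside measurement helps to interpret these results. On these data alone, whether an amine or a carboxylic acid at this position would move the number beyond the scatter remains open.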